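The source may report more compounds than this note shows. Statements on the series, on what has been measured and on what is new or still open speak of the compounds shown alone.

Measured in a functional assay on MCF7 cells (Homo sapiens) for cytotoxicity, read by MTT assay, with a stated time of 72 h; a lower number here means a stronger inhibitor, a higher number a weaker inhibitor:
- compound 1 (`CSC(=S)N[C@H]1CCOC1=O`) gives > 128000 nM as a limit
- compound 2 (`CCCCCCSC(=S)N[C@H]1CCOC1=O`) gives > 128000 nM as a limit

Compound 2 stands only at its limit of > 128000 nM and has no number. Both measured compounds sit at the limit of > 128000 nM in this assay, at which 2 of the 2 values shown sit, and offer no readable potency. Compound 3 (`CCCCCCCCCCCCCCSC(=S)N[C@H]1CCOC1=O`) carries octyl in place of hydrogen on a saturated chain carbon, six bonds along the chain from a sulfur relative to compound 2. Going by the values given here, the only measured step of this kind is a step that the two limits leave unreadable from compound 1 to compound 2 and gives no size to carry over. Compound 3 is therefore expected to remain close to that limit, with no step beyond the scatter expected in this assay on this thin basis. The expected step is an at least 1.0-fold lower number from compound 2 to compound 3 (0.02 log units; that floor lies within the scatter) in no firm direction. Compound 3 is estimated at 120000 nM with an expected range from 40000 nM to 200000 nM for now.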

Compound 3, half-maximal inhibitory concentration: 30500 nM
Compound 3: the middle estimate sits 3.9-fold (0.59 log units) above what was measured, outside the stated range (below it).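

At this place, on a saturated chain carbon, six bonds along the chain from a sulfur, octyl in place of hydrogen gives the only readable potency in the series in this assay, with an at least 4.1-fold lower number from compound 2 to compound 3 (0.62 log units; beyond the scatter). Going by these compounds alone, the earlier pair showed no readable response to a change in this chain, so this step is the first sign that the chain bears on the read-out. The size remains a floor because compound 2 has a limit and no number: the limit of > 128000 nM in this assay, at which 2 of the 3 values shown sit.

As far as these compounds go, whether a longer chain lowers the number further stays open, as does the effect of an amine or a carboxylic acid at the chain end. Where between compound 2 and compound 3 a readable value begins is also open.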